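The compounds below may be only part of what the source reports. "The series", "measured", "known", "first", "only" and "open" are said of these compounds alone.

Measured compounds:
compound 1 `O=C(Cc1nn(CC(=O)N2CCOCC2)c(=O)c2ccccc12)Nc1ccc(OC(F)(F)F)c(Cl)c1` gives 103 nM
compound 2 `CC(C(=O)O)c1nn(Cc2cn3cc(OCC4CC4)c(Cl)cc3n2)c2ccccc2c1=O` gives 31 nM

Of the compounds shown here, two have been measured in a functional assay on CHO cells for antagonist activity at sphingosine 1-phosphate receptor 2 (Homo sapiens), read by GTPgammaS binding; on this read-out higher numbers stand for weaker inhibition and lower numbers for stronger inhibition. Compound 1 gives 103 nM, while compound 2 gives 31 nM, the lower of the two numbers. The gap between them lies beyond the usual scatter, so compound 2 stands as the stronger inhibitor of the pair. The two compounds share no simple one-step relation, so their values are only set side by side here.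

Compound 3 `C[C@@H](C(=O)O)c1nn(Cc2cn3cc(OCC4CC4)c(Cl)cc3n2)c2ccccc2c1=O` has not yet been measured. It differs from compound 2 in this way: the two compounds have the same atoms and bonds; at least one stereo element is drawn with a configuration in one of them and without one in the other: 1 of 1 stereo elements differ; a stereocentre at a saturated chain carbon is drawn without a configuration in compound 2 and R in compound 3. Compound 3 is thus one single enantiomer of the material that compound 2 represents without a drawn configuration. If the R configuration carries the activity, compound 3 is expected to give a somewhat lower number than compound 2; if it does not, the number would rise markedly. On balance the step from compound 2 to compound 3 is expected to be a 1.6-fold lower number from compound 2 to compound 3 (0.19 log units; within the scatter), with a wide range. Compound 3 is therefore estimated at 20 nM, between 7 nM and 120 nM.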

Compound 3, half-maximal inhibitory concentration: 253 nM
Beside the measured number, compound 3's estimate is 13-fold (1.10 log units) below it, and the stated range ends below it.
By their numbers in this assay, from the lowest: compound 2; then compound 1; then compound 3.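

In this assay, the change to the R configuration gives an 8.2-fold higher number from compound 2 to compound 3 (0.91 log units; beyond the scatter), the only step among these compounds that can be read at a single place. It shows that configuration at this saturated chain carbon matters and that the R form does not carry the activity of the material drawn without a configuration; if that material holds both forms, much of its activity would be expected to lie with the S form. With atoms and bonds unchanged, the step can be traced to one source, and the gap arises because of this: the fact that one of compounds 2 and 3 is drawn with a defined configuration and the other without, at the place where they differ

As far as these compounds go, the S enantiomer's own number stays open, as does the make-up of compound 2, whose drawing does not tell whether it holds both forms in equal parts or in some other ratio. Also open, from the compounds shown here alone, is whether the same dependence on configuration would hold if a primary amide took the place of the carboxylic acid, or an ethyl group the place of the methyl group on this carbon.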